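Plasma stability of the ester series: methyl to pentyl

The source may report more compounds than this note shows. Statements on the series, on what has been measured and on what is new or still open speak of the compounds shown alone.

Working notes on the series in an ADME assay on a cell-free system (plasma, Homo sapiens) for metabolic stability, read by LC-MS; a lower number here means that the compound disappears faster, a higher number that the compound lasts longer. Among the compounds with values here, compound 1 `COC(=O)c1cccc(-c2cc(C(=O)Nc3ccncc3)ccc2CN)c1` gives 1.52 h in this assay, the only outright number so far. Compound 2 `NCc1ccc(C(=O)Nc2ccncc2F)cc1-c1cccc(C(=O)O)c1` stands at > 2 h in this assay, which is a limit of the assay and not a number; one of the two values sits there, (the limit of > 2 h in this assay, at which 1 of the 2 values shown sits). Compound 3 `CCCCCOC(=O)c1cccc(-c2cc(C(=O)Nc3ccncc3)ccc2CN)c1` has not yet been measured in this assay. It differs from compound 1 in one place: butyl in place of hydrogen on a saturated chain carbon bound to an oxygen next to a carbonyl group. Within the data shown here, no step between two measured compounds is known here, so nothing yet sets the scale of such a change. In this assay a 1.5-fold lower number from compound 1 to compound 3 (0.18 log units; within the scatter) is expected to be small and, if anything, toward a shorter half-life, staying near the scatter. Compound 3 is estimated at 1 h in this assay, with a range from 0.4 h to 2 h.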

Compound 3, half-life: 0.967 h
Estimate against measurement, compound 3: 1.0-fold (0.01 log units) above, and the stated range covers the measured number.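

Pentyloxycarbonyl in place of methoxycarbonyl gives a 1.6-fold lower number from compound 1 to compound 3 (0.20 log units; within the scatter) in this assay, the first step that sets a scale at this position. Butyl in place of hydrogen on a saturated chain carbon bound to an oxygen next to a carbonyl group therefore keeps the half-life within the scatter, on the evidence of this single pair. Nothing on hand bears on a cause for this step.

On these data alone, whether a branched chain, a longer chain or an amide in place of the ester would also stay within the scatter remains open. Compound 2 stands at > 2 h, which is a limit of the assay and not a number, and its differences from compound 1 in more than one place leave the carboxylic acid without a readable step.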